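The source may hold more compounds than are shown below. What is called first, only, known or untested is meant among the compounds shown, and "the series" means these compounds.

Measured compounds: compound 1 `Cc1ccc(S(=O)(=O)c2cnc3ccc(F)cc3c2N2CCC(C)CC2)cc1` gives 91% in an assay on isolated protein for displacement of a labelled ligand from metabotropic glutamate receptor 5 (Homo sapiens), with a stated time of 60 min, tested at 1 uM; on this read-out lower numbers stand for less inhibition and higher numbers for more inhibition at the one concentration tested (going by the name of the read-out); compound 2 `COc1ccc2ncc(S(=O)(=O)c3ccc(C)cc3)c(N3CCC(C)CC3)c2c1` gives 90% in this assay.

Compound 1 and compound 2 give numbers within the scatter of each other, as a number 1 percentage points lower from compound 1 to compound 2 (within the scatter) shows. Compound 3 `CC1CCN(c2c(S(=O)(=O)c3ccc(C#N)cc3)cnc3ccc(F)cc23)CC1` differs from compound 1 by cyano in place of methyl on an aromatic carbon. Among the measured compounds shown here, the one measured step, a number 1 percentage points lower from compound 1 to compound 2 (within the scatter), concerns a different part of the shared core and does not bear on this change, so nothing measured speaks to the 4-methylphenyl to 4-cyanophenyl exchange. Compound 1 already sits near the top of the read-out. For compound 3 a step of a number 7 percentage points lower from compound 1 to compound 3 (within the scatter) is expected, a modest fall that may not exceed the scatter. Compound 3 is estimated at 84%, between 60% and 96%.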

Compound 3, a percentage reported as inhibition, at one concentration (the size of the read-out at that concentration, not a potency): 75%
Compound 3: the middle estimate sits 9 percentage points above what was measured, and the stated range covers the measured number.
By their numbers in this assay, from the lowest: compound 3; then compounds 2 and 1 (each within the scatter of the next).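

Among the compounds shown here, exchanging 4-methylphenyl for 4-cyanophenyl gives the first step beyond the scatter in this assay, with a number 16 percentage points lower from compound 1 to compound 3 (beyond the scatter). This shows that the aromatic carbon para to a large group responds to this change, although compound 3 still gives 75%, so inhibition at the one concentration tested is reduced, not lost. Nothing available explains the fall. Open, from the compounds shown here alone, is whether a chloro or an amino group on this carbon would hold the level of compound 1. Also open, going by these compounds, is whether cyano would lower the number in the same way with the methoxy of compound 2 on the core.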